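The source may hold more compounds than are shown below. What is called first, only, known or untested is meant among the compounds shown, and "the series" means these compounds.

In a functional assay on MCF7 cells (Homo sapiens) for antiproliferative activity (a lower number here means a stronger inhibitor of growth, a higher number a weaker inhibitor of growth), compound 1 (`COc1ccc(-c2nc3cc(F)ccc3s2)cc1F`) gives 870 nM as its measured value. Compound 2 (`COc1ccc(-c2nc3cc(F)ccc3s2)cc1OC`) gives < 0.1 nM there, which is a limit of the assay and not a number. Compound 3 (`COc1ccc(-c2nc3cc(F)ccc3s2)c(OC)c1OC`) carries one further change on compound 2: methoxy in place of hydrogen on an aromatic carbon, ortho to a large group (methoxy in place of hydrogen on an aromatic carbon). For the measured compounds named here, only one measured step bears on this, an at least 8700-fold lower number from compound 1 to compound 2 (3.93 log units; beyond the scatter) for methoxy in place of fluoro, so a single methoxy change can move the number a long way. That step replaced fluoro rather than hydrogen, so it speaks to size and not to direction. Compound 2 already sits at the limit, so a large step toward a higher number is expected. The estimated move is an at least 50-fold higher number from compound 2 to compound 3 (1.69 log units; beyond the scatter) in the direction of weaker growth inhibition. For compound 3 the estimate is 5 nM with an expected range (0.05 nM to 500 nM).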

Compound 3, concentration for 50% growth inhibition: 23 nM
Compound 3: the middle estimate sits 4.6-fold (0.66 log units) below what was measured; measured number inside the range.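

Adding a methoxy group at this aromatic carbon, ortho to a large group, is far from neutral: in this assay the step is an at least 230-fold higher number from compound 2 to compound 3 (2.36 log units; beyond the scatter). The earlier swap of fluoro for methoxy strengthened growth inhibition, but this methoxy in place of hydrogen weakens it, so on this ring another methoxy group does not automatically bring a stronger inhibitor. The true size of this step stays unknown, and the reason lies with compound 2: the limit of < 0.1 nM in this assay, at which 1 of the 3 values shown sits.

The compounds shown leave open whether a smaller methyl group or an amine on this same carbon would weaken growth inhibition as much as methoxy does. They also leave open how methoxy compares with hydrogen at this carbon when the other two methoxy groups are absent.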